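Swapping chloro for nitro on a second sulfone core

The source may report more compounds than this note shows. Statements on the series, on what has been measured and on what is new or still open speak of the compounds shown alone.

Of the compounds shown here, three have been tested in a functional assay on H157 cells (Homo sapiens) for antiproliferative activity, read by trypan blue exclusion (on this read-out lower numbers stand for stronger inhibition and higher numbers for weaker inhibition), and a fourth awaits measurement. Compound 1 `COc1cc(OC)c(/C=C/S(=O)(=O)Cc2ccc(Cl)cc2)c(OC)c1` gives 15000 nM in this assay. Compound 2 `COc1cc(OC)c(/C=C/S(=O)(=O)Cc2ccc([N+](=O)[O-])cc2)c(OC)c1` differs from it in one place, (nitro in place of chloro on an aromatic carbon), and in this assay compound 2 gives 20000 nM. Among the measured compounds shown here, the step of a 1.3-fold higher number from compound 1 to compound 2 (0.12 log units; within the scatter) is the only measured instance of this change, and it is small.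

Compound 3 `COc1ccc(CS(=O)(=O)/C=C/c2ccc(Cl)cc2)cc1` is built on a different core; the difference between the two cores is not broken down here. In this assay compound 3 gives 3500 nM, the lowest number of the three, and its steps to compound 1 and compound 2 are both beyond the scatter.

Compound 4 `COc1ccc(CS(=O)(=O)/C=C/c2ccc([N+](=O)[O-])cc2)cc1` stands to compound 3 exactly as compound 2 stands to compound 1: nitro in place of chloro on an aromatic carbon. The surroundings of the changed carbon are described in the same words for both pairs, so this is the same change carried onto the core of compound 3.

Because the measured step of a 1.3-fold higher number from compound 1 to compound 2 (0.12 log units; within the scatter) stayed within the scatter, the step from compound 3 to compound 4 is expected to be of similar size, a 1.3-fold higher number from compound 3 to compound 4 (0.11 log units; within the scatter). Compound 4 is therefore estimated at 4500 nM, with the likely range running from 1800 nM to 11000 nM. That range rests on a single prior instance of the change, so it is kept wide.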

Compound 4, half-maximal inhibitory concentration: 7500 nM
Compound 4: the middle estimate sits 1.7-fold (0.22 log units) below what was measured; low and high end bracket the measured number.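

On the core of compound 3, putting nitro in place of chloro on an aromatic carbon gives a 2.1-fold higher number from compound 3 to compound 4 (0.33 log units; beyond the scatter) in this assay, a modest step. Set beside the same change on the core of compound 1, the two steps cannot be told apart: the same change on two cores in this assay, a 1.3-fold higher number (0.12 log units; within the scatter) from compound 1 to compound 2 and a 2.1-fold higher number (0.33 log units; beyond the scatter) from compound 3 to compound 4, 1.6-fold (0.21 log units) apart, within the scatter of two such steps. The change therefore carries across these two cores without a detectable difference in size, but one step lies within the scatter and the other beyond it. Two pairs are too few to set a rule for the series, and they do not show what sets the size of either step.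

The compounds shown carry only chloro or nitro at this position, so they leave open how an amine, a nitrile or a carboxylic acid on the same aromatic carbon would compare on either core. They also leave open whether the swap from chloro to nitro would give a step of similar size on a third core, which a further matched pair could test.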